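The source may hold more compounds than are shown below. What is called first, only, known or untested is meant among the compounds shown, and "the series" means these compounds.

Measured so far in an ADME assay on microsomes from liver (Rattus norvegicus) for metabolic stability, with a stated time of 30 min, tested at 1 uM; on this read-out higher numbers stand for a more stable compound and lower numbers for a less stable compound:
- compound 1 `CC[C@@H]1C(=O)N(C)c2cnc(-n3ccnc3-c3ccc(F)cc3)nc2N1C1COC1`: 80%
- compound 2 `CCC1C(=O)N(C)c2cnc(-n3ccnc3-c3ccc(F)cc3)nc2N1c1ccc(F)cc1`: 11%

Compound 2 stands lowest of the two, beyond the scatter from compound 1. Compound 3 `CCC1C(=O)N(C)c2cnc(-n3ccnc3-c3ccc(F)cc3)nc2N1C1CCC(F)(F)C1` carries 3,3-difluorocyclopentyl in place of 4-fluorophenyl on the same nitrogen (3,3-difluorocyclopentyl in place of 4-fluorophenyl on a nitrogen on an aromatic ring in a ring). Going by the values given here, no measured step isolates this change, so the expectation is loose. Among the compounds with values here, with compound 2 at 11% as the low reference and compound 1 at 80% as the only higher value, a moderate upward step in this assay is expected. The expected change is a number 27 percentage points higher from compound 2 to compound 3 (beyond the scatter) and would lie beyond the scatter. For compound 3 the estimate is 38% within an expected range of 14% to 66% for this read-out.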

Compound 3, percent of the compound remaining: 8%
Compound 3: middle estimate off by 30 percentage points, on the high side; measured number below the stated range.
By their numbers in this assay, from the lowest: compounds 3 and 2 (each within the scatter of the next); then compound 1.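

In this assay, 3,3-difluorocyclopentyl in place of 4-fluorophenyl on this nitrogen gives a number 3 percentage points lower from compound 2 to compound 3 (within the scatter). At this position, the non-aromatic carbon ring and the aromatic carbon ring therefore cannot be told apart on this read-out. Nothing available explains this result.

Open, going by these compounds, is whether plain cyclopentyl or a piperidine ring on this nitrogen would read like compound 3. Also open, on these data alone, is how a longer chain in place of the ethyl group would read with either ring.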